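The compounds below may be only part of what the source reports. "The series", "measured", "known", "first", "only" and "open" are said of these compounds alone.

Measured so far:
- compound 1, `Cc1nc(NC(=O)NCc2ccccc2)c2nn(-c3ccccc3)cc2n1`: 26%
- compound 2, `O=C(Nc1nc(-c2ccccc2)nc2cn(-c3ccccc3)nc12)c1ccncc1`: 1%

Two compounds have been run in an assay on CHO cells for displacement of a labelled ligand from adenosine receptor A1 (Homo sapiens), read by scintillation counting, with a stated time of 120 min, tested at 1 uM; a lower number here means less inhibition, a higher number more inhibition at the concentration tested (going by the name of the read-out). In this assay compound 1 gives 26%, and compound 2 gives 1%. Compound 2 therefore stands lowest of the two numbers, and its nearest neighbour, compound 1, is higher by a margin beyond the scatter. The two differ in more than one place, so no single step can be read from them.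

Compound 3, `Cc1nc(NC(=O)c2ccncc2)c2nn(-c3ccccc3)cc2n1`, is not yet measured. It comes from compound 2 by one change: methyl in place of phenyl on an aromatic carbon. Within the data shown here, compound 1 also carries methyl at this position, though with a different amide, so no measured step isolates this change.

The step from compound 2 to compound 3 in this assay is expected to be small and upward, a number 9 percentage points higher from compound 2 to compound 3 (within the scatter), possibly within the scatter. Compound 3 is estimated at 10%, in the range 0% to 30%.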

Compound 3, a percentage reported as inhibition, at one concentration (the size of the read-out at that concentration, not a potency): 12%
Compound 3: the middle estimate sits 2 percentage points below what was measured; the measured number falls inside the stated range.
By their numbers in this assay, from the lowest: compound 2; then compound 3; then compound 1.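

In this assay, the aromatic carbon between two ring nitrogen atoms now has a reading of its own: with the ((pyridin-4-yl)carbonyl)amino group held constant, methyl in place of phenyl gives a number 11 percentage points higher from compound 2 to compound 3 (beyond the scatter). With methyl held at that carbon, pyridin-4-yl in place of benzylamino on the carbonyl carbon gives a number 14 percentage points lower from compound 1 to compound 3 (beyond the scatter), so the number responds to the group on the carbonyl carbon as well as to the group on the aromatic carbon, each step being modest. Nothing at hand accounts for either step.

From the compounds shown here alone, whether an ethyl group, a longer chain or an amine at the same aromatic carbon would move the number further remains open. Going by these compounds, the effect of methyl or phenyl at this carbon alongside other groups on the carbonyl carbon is also open, as each change has been read only once.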